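The source may report more compounds than this note shows. Statements on the series, on what has been measured and on what is new or still open speak of the compounds shown alone.

In a functional assay on SEM cells (Homo sapiens) for cytotoxicity, with a stated time of 72 h (on this read-out lower numbers stand for an effect already at smaller amounts and higher numbers for an effect only at larger amounts of compound), compound 1 `CCOC(=O)/C(C)=C/c1cc(/C=C/[C@](C)(/C=C/c2ccc(OC)cc2)CCC=C(C)C)ccc1O` gives > 36600 nM, which is a limit and not a number. Compound 2 `COc1ccc(/C=C/[C@@](C)(/C=C/c2ccc(O)c(/C=C/C(=O)OCc3ccccc3)c2)CCC=C(C)C)cc1` gives > 36600 nM, which is also a limit. Among the compounds with values here, compound 2 therefore has no exact position on the scale, and the only evidence on where it stands is the limit of > 36600 nM in this assay, at which 2 of the 2 values shown sit. Within the data shown here, the one measured change is a step that the two limits leave unreadable from compound 1 to compound 2, so it offers no size to carry forward.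

Compound 3 `COc1ccc(/C=C/[C@@](C)(/C=C/c2ccc(O)c(/C=C/C(C)=O)c2)CCC=C(C)C)cc1` keeps the rest of compound 2 but has methyl in place of benzyloxy on a carbonyl carbon, (methyl in place of benzyloxy on a carbonyl carbon). Put another way, 2-(benzyloxycarbonyl)ethenyl becomes 2-acetylethenyl. Among the measured compounds shown here, no measured step covers this change, so any expectation is loose. Since compound 2 gives > 36600 nM, a readable result in this assay would most likely point toward lower numbers, though another limit is at least as likely. The expected change is an at least 1.4-fold lower number from compound 2 to compound 3 (0.16 log units; that floor lies within the scatter), a modest step at best. For compound 3, the estimated value is 25000 nM, with an expected range from 8000 nM to 50000 nM.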

Compound 3, half-maximal effective concentration: 8670 nM
The estimate for compound 3 lay 2.9-fold (0.46 log units) above the measured number; the range from low to high includes it.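

In this assay, methyl in place of benzyloxy on a carbonyl carbon gives an at least 4.2-fold lower number from compound 2 to compound 3 (0.62 log units; beyond the scatter), so a change at this carbonyl carbon can bring a limit down to a readable number. The same 2-acetylethenyl group, in place of 2-(ethoxycarbonyl)prop-1-en-1-yl, gives an at least 4.2-fold lower number from compound 1 to compound 3 (0.62 log units; beyond the scatter), and both of these steps are floors rather than full sizes. The step between compound 1 and compound 2 still cannot be read, and each of the two compounds rests on a limit, not a number: the limit of > 36600 nM in this assay, at which 2 of the 3 values shown sit.

Within the data shown here, with compound 3 as the only compound carrying a number, it remains open whether the drop comes with methyl itself or simply with the loss of benzyloxy and its aromatic ring. An amine or a longer carbon chain such as propyl on the same carbonyl carbon would help to show whether the read-out follows the size of this group or depends on something more specific to methyl.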